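The compounds below may be only part of what the source reports. "The series", "measured", "known", "first", "only" and "open" are said of these compounds alone.

Measured so far in an assay on HEK293 cells for inhibition of Steryl-sulfatase (Homo sapiens), tested at 0.1 uM; a lower number here means a weaker effect, a higher number a stronger effect of the compound at the concentration tested:
compound 1 `CN(CCCN1CCCCC1)c1ccc(C(=O)N2CCc3ccc(OS(N)(=O)=O)cc3C2)cc1` gives 17.4%
compound 2 `CCN(Cc1cccc(Br)c1)c1ccc(C(=O)N2CCc3ccc(OS(N)(=O)=O)cc3C2)cc1` gives 80.2%
compound 3 `CCN(Cc1ccc(F)cc1)c1ccc(C(=O)N2CCc3ccc(OS(N)(=O)=O)cc3C2)cc1` gives 69.1%

Compound 3 stands second highest of the three numbers in this assay. The step of a number 11.1 percentage points lower from compound 2 to compound 3 (beyond the scatter) is modest, while a number 51.7 percentage points higher from compound 1 to compound 3 (beyond the scatter) is large.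

Compound 4 `CCN(Cc1ccc(Br)cc1)c1ccc(C(=O)N2CCc3ccc(OS(N)(=O)=O)cc3C2)cc1` differs from compound 3 in one place: bromo in place of fluoro on an aromatic carbon. Among the compounds with values here, the only measured step that touches this swap is a number 11.1 percentage points lower from compound 2 to compound 3 (beyond the scatter), where the benzyl group changed both its halogen and the halogen's position, so it bears on the present step only in part; there the bromine went with the higher number. A small rise in this assay is therefore expected, a number 6.9 percentage points higher from compound 3 to compound 4 (within the scatter), which may stay within the scatter.

Compound 4 is estimated at 76% in this assay, with a range from 62% to 88%.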

Compound 4, a percentage reported as inhibition, at one concentration (the size of the read-out at that concentration, not a potency): 78.2%
The estimate for compound 4 lay 2.2 percentage points below the measured number; measured number inside the range.
By their numbers in this assay, from the lowest: compound 1; then compounds 3, 4 and 2 (each within the scatter of the next, the first and the last beyond it).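

Swapping fluoro for bromo alone gives (a number 9.1 percentage points higher from compound 3 to compound 4 (within the scatter)), and 4-bromophenyl in place of 3-bromophenyl gives (a number 2 percentage points lower from compound 2 to compound 4 (within the scatter)), so neither the halogen nor its place on the ring separates these compounds in this assay. The gap to the piperidine-bearing side chain stays wide with bromine at this position (a number 60.8 percentage points higher from compound 1 to compound 4 (beyond the scatter)). Nothing shown explains these numbers. Open, going by these compounds, is whether a plain benzyl group, with no halogen, would hold the number. On these data alone, a methoxy group or a carboxylic acid on that ring, or a propyl group replacing the ethyl on the nitrogen, also remains untested here.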